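Indole to furan on the amide of compound 3

The source may report more compounds than this note shows. Statements on the series, on what has been measured and on what is new or still open speak of the compounds shown alone.

Three compounds of the series have been run in an assay on HEK293 cells for binding affinity to Urotensin-2 receptor (Homo sapiens), read by radioligand binding; on this read-out lower numbers stand for stronger inhibition and higher numbers for weaker inhibition. Compound 1 `COc1ccc(C(=O)N[C@H]2CCN(Cc3ccc(OCCCN(C)C)cc3)C2)cc1OC` returns a limit of the method rather than a number, < 10000 nM. Compound 2 `CN(C)CCCOc1ccc(CN2CC[C@H](NC(=O)c3ccc(-c4ccccc4)cc3)C2)cc1` likewise returns only a limit, < 10000 nM. Among the measured compounds shown here, compound 3 `CC(C)C[C@H](NC(=O)c1cc2ccccc2[nH]1)C(=O)N[C@H]1CCN(Cc2ccc(OCCCN(C)C)cc2)C1` is the single member with a numerical result in this assay, at 501 nM, so it stands as the only fixed point among the values shown; the other two sit at the limit of < 10000 nM in this assay, at which 2 of the 3 values shown sit, and cannot be ordered against it or against each other. For the measured compounds named here, no pair of measured compounds differs in one place, so no measured step is available.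

Compound 4 `CC(C)C[C@H](NC(=O)c1ccco1)C(=O)N[C@H]1CCN(Cc2ccc(OCCCN(C)C)cc2)C1` is the next analogue to go through this assay. Against compound 3 the difference is furan-2-yl in place of 1H-indol-2-yl on a carbonyl carbon, with the rest of the molecule unchanged. The smaller ring leaves the shared core intact but removes most of the bicyclic group that compound 3 carries. Going by the values given here, with no measured step to lean on, the expectation from compound 3 to compound 4 is a loss of affinity beyond the usual scatter, a 6.0-fold higher number from compound 3 to compound 4 (0.78 log units; beyond the scatter). Compound 4 is therefore estimated at 3000 nM in this assay, within a range of 800 nM to 12000 nM, with a real chance that only a limit is returned.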

Compound 4, inhibition constant: 631 nM
Compound 4: middle estimate off by 4.8-fold (0.68 log units), on the high side; measured number outside the range, below it.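

Furan-2-yl in place of 1H-indol-2-yl on a carbonyl carbon gives a 1.3-fold higher number from compound 3 to compound 4 (0.10 log units; within the scatter) in this assay, the first step in the series that can be read. For this pair, the six-membered aromatic ring and the hydrogen-bond donor of the 1H-indol-2-yl group can both leave without a change beyond the scatter, and the hydrogen-bond acceptor that enters with furan-2-yl makes no difference beyond it either. Compound 1 and compound 2 each return a limit, and no step to or from either can be read: the limit of < 10000 nM in this assay, at which 2 of the 4 values shown sit.

Open, going by these compounds, is whether an aromatic ring on this carbonyl matters at all, a question that an acetyl group would address, and whether sulfur in place of the furan oxygen, as in thiophen-2-yl, would leave the value within the scatter. Equally open, on these data alone, is how far the values of compound 3 and compound 4 rest on the shared core, which stays unchanged in this step.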